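Working notes on two measured inhibitors and one candidate

A few compounds are considered here, and "the series" means these few. Any claim that something is new, unique, unknown or untested is made for them only; others in the source may bear on it.

Measured so far:
compound 1, `Oc1c(C(Nc2ccccn2)c2ccccc2Cl)ccc2cccnc12`, 500 nM in an assay for inhibition of protein disulfide-isomerase (Homo sapiens), with a stated time of 1 h; on this read-out higher numbers stand for weaker inhibition and lower numbers for stronger inhibition
compound 2, `Oc1c(C(c2ccc(F)cc2)N2CCCCC2)ccc2scnc12`, 570 nM

Compound 1 gives the lower of the two numbers in this assay, but its gap to compound 2 lies within the usual scatter, so the two values cannot be told apart, and the compounds differ in several places at once, so nothing about any single change can be read from them.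

Compound 3, `Cc1ccc(C)c(C(Nc2ccccn2)c2ccc3cccnc3c2O)c1`, is not yet measured. Against compound 1 the change is 2,5-dimethylphenyl in place of 2-chlorophenyl on a saturated chain carbon bound to an aromatic carbon and a nitrogen on an aromatic ring. Within the data shown here, no measured pair shows the effect of such a swap, so there is no basis for expecting a step in either direction beyond the scatter. The expectation is therefore that the step of a 1.2-fold higher number from compound 1 to compound 3 (0.08 log units; within the scatter) stays within the scatter.

On that basis compound 3 is estimated at 600 nM in this assay, with a range from 200 nM to 1800 nM, the width reflecting the absence of any measured step of this kind.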

Compound 3, half-maximal inhibitory concentration: 730 nM
Estimate against measurement, compound 3: 1.2-fold (0.09 log units) below; the measured number falls inside the stated range.
By their numbers in this assay, from the lowest: compounds 1, 2 and 3 (each within the scatter of the next).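

At the saturated chain carbon bound to an aromatic carbon and a nitrogen on an aromatic ring, the series now has its first comparison that differs in one place: in this assay, putting 2,5-dimethylphenyl in place of 2-chlorophenyl gives a 1.5-fold higher number from compound 1 to compound 3 (0.16 log units; within the scatter) on the shared core. At this position, then, the two substituted phenyl groups cannot be told apart on this read-out, even though one carries chlorine and the other carries only carbon, so this change gives no sign of a real difference in inhibition. The compounds shown offer no independent measurement that would account for this outcome.

Still open, going by these compounds, is whether the read-out at this position would move beyond the scatter with a phenyl ring bearing a carboxylic acid or a primary amine, or with a saturated cyclohexyl group in place of the aromatic ring. Compound 2 differs from compound 1 and compound 3 in several places, so it cannot show how the groups at this position behave on its own core, and a single methyl and a single chlorine also remain unseparated.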